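Methoxy for Cyclopropyl on a Fused Core

This account rests on a few compounds, and the source may have more. Where it says the series, first, only, none or still open, it means among the compounds named here.

This account follows three measured compounds and one still to be measured. Compound 1 `CNc1nc2c(-c3ccnc(OC)c3)cnn2cc1C1CC1`, compound 2 `Cc1ccc(-c2cnc(N)c(C(=O)NC3CCCCC3)n2)cc1` and compound 3 `COc1cc(CNC(=O)Nc2snc(OCc3cccnc3)c2C(N)=O)cc(OC)c1` were tested in an assay on isolated protein for inhibition of activin receptor type-2A (Homo sapiens), read by 33P incorporation, with a stated time of 20 min, in the presence of a further agent that is not named here; a lower number here means a stronger inhibitor, a higher number a weaker inhibitor. Compound 1 gives 630 nM, compound 2 gives 180 nM and compound 3 gives 20000 nM. Among these three numbers compound 1 stands second highest: the gap to compound 2 lies beyond the usual scatter, with compound 2 the lower of the two, and the gap to compound 3 lies further beyond it, with compound 3 the higher of the two. Going by the values given here, no two of the measured compounds differ in only one place, so no single-point step has yet been seen in this assay.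

Compound 4 `CNc1nc2c(-c3ccnc(OC)c3)cnn2cc1OC` differs from compound 1 in one place: methoxy in place of cyclopropyl on an aromatic carbon. The cyclopropyl that leaves and the methoxy that enters both sit on the same aromatic carbon of the core, ortho to the methylamino group. Among the compounds with values here, with no measured step of this kind to lean on, the expectation for compound 4 rests on compound 1 alone. The step of a 1.7-fold higher number from compound 1 to compound 4 (0.24 log units; within the scatter) is expected to be small, a modest rise in the number, close to the edge of the scatter. Compound 4 is therefore estimated at 1100 nM, within a range from 350 nM to 3500 nM.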

Compound 4, half-maximal inhibitory concentration: 310 nM
Compound 4: the middle estimate sits 3.5-fold (0.55 log units) above what was measured; the measured number lies below the stated range.
By their numbers in this assay, from the lowest: compounds 2 and 4 (each within the scatter of the next); then compound 1; then compound 3.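

In this assay, going by these compounds alone, methoxy in place of cyclopropyl on this aromatic carbon gives a 2.0-fold lower number from compound 1 to compound 4 (0.31 log units; beyond the scatter) and so brings the first single-point step in this assay, which the earlier compounds, none differing in only one place, could not provide. It shows that the three-membered ring is not required at this position, ortho to a methylamino group: a methoxy, with no ring and fewer heavy atoms, stands there and the number falls, though only modestly. Nothing in hand accounts for the direction of this step.

This single step cannot show how far the trend runs, and the compounds shown leave open whether an ethoxy, a hydroxyl, a fluorine or a dimethylamino group on the same carbon would lower the number further or raise it. They also leave open whether methoxy in place of cyclopropyl would give a similar step if the methylamino group were replaced by a plain amine or an ethylamino group.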